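Trifluoromethyl to Methyl on a Thiourea Amide Scaffold

The source may hold more compounds than are shown below. What is called first, only, known or untested is meant among the compounds shown, and "the series" means these compounds.

Compound 1, `NC(=O)c1c(NC(=O)c2ccccc2Br)sc2c1CCN(C(=S)Nc1ccccc1Cl)C2`, gives 12900 nM in a functional assay on MKN-74 cells (Homo sapiens) for antiproliferative activity, with a stated time of 24 h; a lower number here means a stronger inhibitor, a higher number a weaker inhibitor.
Compound 2, `NC(=O)c1c(NC(=O)c2ccccc2C(F)(F)F)sc2c1CCN(C(=S)Nc1ccccc1Cl)C2`, gives 21900 nM in this assay.

Compound 2 holds the highest of the two numbers; its nearest neighbour is compound 1, and the step of a 1.7-fold higher number from compound 1 to compound 2 (0.23 log units; within the scatter) lies within the scatter. Compound 3, `Cc1ccccc1C(=O)Nc1sc2c(c1C(N)=O)CCN(C(=S)Nc1ccccc1Cl)C2`, differs from compound 2 by methyl in place of trifluoromethyl on an aromatic carbon. Among the compounds with values here, only that one measured step bears on this change, and it was small, so a step beyond the scatter is not expected here; the expected step is a 1.5-fold lower number from compound 2 to compound 3 (0.16 log units; within the scatter). Compound 3 is therefore estimated at 15000 nM, within 6000 nM to 40000 nM.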

Compound 3, half-maximal inhibitory concentration: 11000 nM
Compound 3: the middle estimate sits 1.4-fold (0.13 log units) above what was measured; low and high end bracket the measured number.
By their numbers in this assay, from the lowest: compounds 3, 1 and 2 (each within the scatter of the next).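

Bromo, trifluoromethyl and methyl have now been compared on the same aromatic carbon of the shared core. In this assay the steps read a 2.0-fold lower number from compound 2 to compound 3 (0.30 log units; within the scatter) and a 1.2-fold lower number from compound 1 to compound 3 (0.07 log units; within the scatter) and so replacing either group with methyl, which has one heavy atom against four in trifluoromethyl, gives no difference that stands clear of the scatter. No measured evidence here bears on the reason for this result. The compounds shown leave open whether an amine or a carboxylic acid on this carbon would give a number beyond the scatter.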